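The source may report more compounds than this note shows. Statements on the series, on what has been measured and on what is new or still open speak of the compounds shown alone.

Measured compounds:
compound 1, `Cc1ccc2[nH]c(-c3ccc(-c4ccc(-c5ccc(N(C)C)cc5)cc4)cc3)nc2c1`, 6240 nM
compound 2, `Cc1ccc2[nH]c(-c3ccc(-c4ccc(-c5cccc(Cl)c5)cc4)cc3)nc2c1`, 2260 nM
compound 3, `CN(C)c1ccc(-c2ccc(-c3ccc(-c4nc5ccccc5[nH]4)cc3)cc2)cc1`, 39300 nM

Three compounds were measured in a functional assay on KB cells (Homo sapiens) for inhibition, read by sulforhodamine B assay; on this read-out lower numbers stand for stronger inhibition of growth and higher numbers for weaker inhibition of growth. Compound 1 and compound 2 share one core, and compound 3 carries a different core; the two cores differ by hydrogen in place of methyl on an aromatic carbon, and in this assay that change gave a 6.3-fold higher number from compound 1 to compound 3 (0.80 log units; beyond the scatter). Compound 2 differs from compound 1 by 3-chlorophenyl in place of 4-(dimethylamino)phenyl on an aromatic carbon, and the step was a 2.8-fold lower number from compound 1 to compound 2 (0.44 log units; beyond the scatter).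

Compound 4, `Clc1cccc(-c2ccc(-c3ccc(-c4nc5ccccc5[nH]4)cc3)cc2)c1`, has not been measured. It differs from compound 3 by 3-chlorophenyl in place of 4-(dimethylamino)phenyl on an aromatic carbon. This is the same change as that from compound 1 to compound 2, made on the core of compound 3 rather than on the core of compound 1. Because a 2.8-fold lower number from compound 1 to compound 2 (0.44 log units; beyond the scatter) was modest but beyond the scatter, a step of similar direction and size is expected here, which gives a 2.8-fold lower number from compound 3 to compound 4 (0.45 log units; beyond the scatter). This rests on a single measured pair, so the expectation is held loosely. Compound 4 is estimated at 14000 nM, with a likely range from 5000 nM to 40000 nM.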

Compound 4, concentration for 50% growth inhibition: 32300 nM
Compound 4: middle estimate off by 2.3-fold (0.36 log units), on the low side; the measured number falls inside the stated range.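

In this assay, 3-chlorophenyl in place of 4-(dimethylamino)phenyl on the core of compound 3 gave a 1.2-fold lower number from compound 3 to compound 4 (0.09 log units; within the scatter), and this step cannot be told apart from the one on the core of compound 1: the same change on two cores in this assay, a 2.8-fold lower number (0.44 log units; beyond the scatter) from compound 1 to compound 2 and a 1.2-fold lower number (0.09 log units; within the scatter) from compound 3 to compound 4, 2.3-fold (0.36 log units) apart, within the scatter of two such steps. Hydrogen in place of methyl, read with 3-chlorophenyl in place, gave a 14-fold higher number from compound 2 to compound 4 (1.16 log units; beyond the scatter), and this step also agrees with its earlier counterpart: the same change on two cores in this assay, a 6.3-fold higher number (0.80 log units; beyond the scatter) from compound 1 to compound 3 and a 14-fold higher number (1.16 log units; beyond the scatter) from compound 2 to compound 4, 2.3-fold (0.36 log units) apart, within the scatter of two such steps. Within the data shown here, the methyl change thus went the same way on both pairs, while the aryl change is beyond the scatter on one core and within it on the other, so the data show no difference between the cores but do not show that either change carries over at a fixed size, as each rests on only two steps.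

The compounds shown leave open how these two cores would respond to other groups at this place, such as a phenyl bearing a carboxylic acid or a primary amine. They also leave open whether an ethyl or a longer chain in place of the methyl would follow the same trend.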